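The source may hold more compounds than are shown below. What is called first, only, known or untested is meant among the compounds shown, and "the series" means these compounds.

Compound 3 `COc1cc(/C=C/C(=O)C2=C(/C=C/c3ccc(O)c(OC)c3)NC(=S)NC2c2ccccc2)ccc1O` is the weakest-looking of three measured compounds in a functional assay, with a stated time of 20 min, tested at 20 uM (a higher number here means a stronger effect of the compound at the concentration tested, a lower number a weaker effect), where compound 3 gives 38%. Compound 1 `COc1cc(/C=C/C(=O)C2=C(/C=C/c3ccc(O)c(OC)c3)NC(=O)NC2c2ccc(O)cc2)ccc1O` gives 84.6% in this assay, and compound 2 `COc1cc(/C=C/C(=O)C2=C(/C=C/c3ccc(O)c(OC)c3)NC(=O)NC2c2ccccc2Cl)ccc1O` gives 46%; the gap between compound 3 and compound 2 lies within the scatter, while compound 1 stands well above both.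

Compound 4 `COc1cc(/C=C/C(=O)C2=C(/C=C/c3ccc(O)c(OC)c3)NC(=S)NC2c2c(Cl)cccc2Cl)ccc1O` differs from compound 3 by 2,6-dichlorophenyl in place of phenyl on a saturated ring carbon. For the measured compounds named here, the only measured step that touches this position is a number 38.6 percentage points lower from compound 1 to compound 2 (beyond the scatter), a large loss when a chlorine-bearing ring replaced a hydroxyl-bearing one. For compound 4 the estimate is therefore a small drop, a number 10 percentage points lower from compound 3 to compound 4 (within the scatter), and compound 4 is expected to give 28%, between 10% and 48%.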

Compound 4, a percentage reported as activity, at one concentration (the size of the read-out at that concentration, not a potency): 43.2%
Estimate against measurement, compound 4: 15.2 percentage points below; low and high end bracket the measured number.
By their numbers in this assay, from the lowest: compounds 3, 4 and 2 (each within the scatter of the next); then compound 1.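

The change gives a number 5.2 percentage points higher from compound 3 to compound 4 (within the scatter) in this assay, so on this saturated ring carbon the 2,6-dichlorophenyl and phenyl groups cannot be told apart. The large step, a number 38.6 percentage points lower from compound 1 to compound 2 (beyond the scatter), swapped a hydroxyl-bearing ring for a chlorine-bearing one, whereas here adding chlorine to a plain phenyl ring gives no readable change. Nothing available explains this result. Still open, on these data alone, is how an amine or a carboxylic acid on this phenyl ring would read. Also open, as far as these compounds go, is whether 4-hydroxyphenyl, which gives compound 1 84.6%, would keep that number on the core of compound 3.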